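Lengthening the Saturated Chain of Compound 3

The source may report more compounds than this note shows. Statements on the series, on what has been measured and on what is new or still open speak of the compounds shown alone.

Values in a functional assay on brain (Rattus norvegicus, strain Wistar) for inhibition; on this read-out lower numbers stand for stronger inhibition and higher numbers for weaker inhibition:
Compound 1 `Cc1[nH]c(=O)n(C2CCCCC2)c1-c1ccc(OC(C)C)cc1`: 13000 nM
Compound 2 `Cc1[nH]c(=O)n(C2CCCCC2)c1-c1ccc(CC(C)C)cc1`: 10900 nM
Compound 3 `CCCCCc1ccc(-c2c(C)[nH]c(=O)n2C2CCCCC2)cc1`: 10600 nM

These three compounds share one core and differ only in the group on its aromatic ring. Compound 3, at 10600 nM, stands within the scatter of both compound 1 and compound 2, so the three cannot be ranked on these numbers.

The next compound is compound 4 `CCCCCCc1ccc(-c2c(C)[nH]c(=O)n2C2CCCCC2)cc1`, which differs from compound 3 by a single change: methyl in place of hydrogen on a saturated chain carbon, five bonds along the chain from an aromatic carbon. That change is methyl in place of hydrogen on a saturated chain carbon, five bonds along the chain from an aromatic carbon.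

Going by the values given here, two measured steps bear most directly on it. One exchanges one saturated chain for another, butyl in place of isopropyl, and gives a 1.0-fold lower number from compound 2 to compound 3 (0.01 log units; within the scatter). The other, pentyl in place of isopropoxy, gives a 1.2-fold lower number from compound 1 to compound 3 (0.09 log units; within the scatter). Both lie within the scatter, and neither points in a direction that could be carried forward. Among the compounds with values here, no measured step adds a single methyl to this chain, so the comparison is indirect.

The expected result is a 1.1-fold lower number from compound 3 to compound 4 (0.03 log units; within the scatter), which would be no change beyond the scatter. For compound 4 the estimated value is 10000 nM, with an expected range from 5000 nM to 20000 nM.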

Compound 4, half-maximal inhibitory concentration: 13700 nM
The estimate for compound 4 lay 1.4-fold (0.14 log units) below the measured number, and the stated range covers the measured number.
By their numbers in this assay, from the lowest: compounds 3, 2, 1 and 4 (each within the scatter of the next).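

In this assay, going by these compounds alone, methyl in place of hydrogen on a saturated chain carbon, five bonds along the chain from an aromatic carbon, gives a 1.3-fold higher number from compound 3 to compound 4 (0.11 log units; within the scatter) and so provides the first direct reading of a single added methyl on this chain, a step that stays within the scatter. The hexyl group of compound 4 also stays within the scatter of the two shorter or branched groups, with a 1.3-fold higher number from compound 2 to compound 4 (0.10 log units; within the scatter) and a 1.1-fold higher number from compound 1 to compound 4 (0.02 log units; within the scatter) as the steps, so isopropoxy, isobutyl, pentyl and hexyl cannot be told apart on these numbers, and lengthening the chain by this one carbon shows no measurable effect in either direction. No independent evidence is available to account for this result.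

The compounds shown leave open whether a chain longer than hexyl, or an amine or a carboxylic acid carried on this chain, would move the number beyond the scatter. From the compounds shown here alone, the rest of the shared core is the same in all four compounds, so what a change there would do also remains open.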